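From ethyl to cyclopropylmethyl on a weak growth inhibitor

A few compounds are considered here, and "the series" means these few. Any claim that something is new, unique, unknown or untested is made for them only; others in the source may bear on it.

Compound 1 `COc1cc2ncn([C@@H]3O[C@H](CO)[C@@H](O)[C@H]3O)c2cc1OC` gives > 100000 nM (a limit of the assay, not a number)
Compound 2 `Clc1cc2nc(-c3ccccc3Cl)[nH]c2cc1Cl` gives 23000 nM (a measured number)
Compound 3 `CCn1c(C(F)(F)F)nc2cc(Cl)c(Cl)cc21` gives 95300 nM (a measured number)

All three compounds were tested in a functional assay on HCT-116 cells (Homo sapiens) for cytotoxicity, read by MTT assay, with a stated time of 48 h (a lower number here means a stronger inhibitor of growth, a higher number a weaker inhibitor of growth), and all three are weak. Compound 1 reached only a limit, > 100000 nM, so it gives no true number. Of the two real numbers, compound 3 has the higher, 95300 nM, and compound 2 the lower, 23000 nM, a gap beyond the usual scatter.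

Compound 4 `FC(F)(F)c1nc2cc(Cl)c(Cl)cc2n1CC1CC1` has not been measured yet. It has cyclopropyl in place of methyl on a saturated chain carbon bound to an aromatic nitrogen and is otherwise the same as compound 3. Put another way, ethyl becomes cyclopropylmethyl.

Among the measured compounds shown here, no measured pair here differs in just one place, so the size of this step has no direct precedent. In this assay a small step is expected, within the scatter or slightly beyond it, and if anything toward a lower number. The expected change is a 1.6-fold lower number from compound 3 to compound 4 (0.20 log units; within the scatter) in this estimate. For compound 4 the estimated value is 60000 nM, with an expected range from 20000 nM to 100000 nM in this assay.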

Compound 4, concentration for 50% growth inhibition: 61300 nM
Estimate against measurement, compound 4: 1.0-fold (0.01 log units) below; the measured number falls inside the stated range.
By their numbers in this assay, from the lowest: compound 2; then compounds 4 and 3 (each within the scatter of the next). At a limit, above all of these: compound 1.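

In this assay, among the compounds shown here, this is the only step that can be read at one place, a saturated chain carbon bound to an aromatic nitrogen, and cyclopropyl in place of methyl there gives a 1.6-fold lower number from compound 3 to compound 4 (0.19 log units; within the scatter). The three-membered ring can therefore be added at this place with no clear gain or loss in growth inhibition, and this measurement does not separate ethyl from cyclopropylmethyl. Both compounds remain weak inhibitors of growth, yet both give real numbers, so the step can be read rather than being lost at the top of the measurable range: the limit of > 100000 nM in this assay, at which 1 of the 4 values shown sits.

As far as these compounds go, one step within the scatter does not show how much this place can accept, so it remains open whether a longer chain, an amine or a carboxylic acid here would move the number beyond the scatter, and in which direction. Also open, from the compounds shown here alone, is what the trifluoromethyl group contributes to the shared core of compound 3 and compound 4, since telling that would take a step at that other place.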